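The source may report more compounds than this note shows. Statements on the series, on what has been measured and on what is new or still open speak of the compounds shown alone.

The measured compounds:
Compound 1, `CS(=O)(=O)NC(=O)CCc1cn(-c2ccc(Br)cc2)nc1-c1ccc(Cl)cc1`: in a physicochemical assay for solubility, in phosphate buffer, measured as thermodynamic solubility, at pH 7.4 (on this read-out lower numbers stand for lower solubility and higher numbers for higher solubility), compound 1 gives 170000 nM.
Compound 2, `CS(=O)(=O)NC(=O)CCc1cn(-c2ccc(Cl)cc2)nc1-c1ccc(Cl)cc1`: compound 2 gives 100000 nM.
Compound 3, `CS(=O)(=O)NC(=O)C1CC1c1cn(-c2ccc(Cl)cc2)nc1-c1ccncc1`: compound 3 gives 200000 nM.

Compound 4, `CS(=O)(=O)NC(=O)C1CC1c1cn(-c2ccc(Br)cc2)nc1-c1ccncc1`, has not been measured yet. It differs from compound 3 by bromo in place of chloro on an aromatic carbon. The same change occurs once more among these compounds, from compound 2 to compound 1, where it reads (bromo in place of chloro on an aromatic carbon), and there the step was a 1.7-fold higher number from compound 2 to compound 1 (0.23 log units; within the scatter). The cores of compound 2 and compound 3 differ in more than one place; that difference is not broken down here. For the measured compounds named here, the step from compound 3 to compound 4 is expected to be small as well, a 1.3-fold higher number from compound 3 to compound 4 (0.10 log units; within the scatter), and this rests on the single earlier step, a 1.7-fold higher number from compound 2 to compound 1 (0.23 log units; within the scatter). Compound 4 is therefore estimated at 250000 nM, expected to fall between 120000 nM and 500000 nM.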

Compound 4, solubility: 155000 nM
Compound 4: middle estimate off by 1.6-fold (0.21 log units), on the high side, within the range that was stated.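

In this assay putting bromo in place of chloro gives a 1.3-fold lower number from compound 3 to compound 4 (0.11 log units; within the scatter) on one core, and on the other core the same change gave a 1.7-fold higher number from compound 2 to compound 1 (0.23 log units; within the scatter) and both steps lie within the usual scatter of repeated measurements. The two steps point in opposite directions, yet neither lies beyond the scatter, and two pairs do not show that the change would stay this small on a further core. Nothing measured here speaks to why the numbers fall as they do.

The compounds shown carry only chloro or bromo on this aromatic carbon, which leaves open how fluoro, a nitrile or an amine would read there. Also open, as far as these compounds go, is whether the step stays as small on a core carrying a longer chain.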